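Cyclobutane Thioether Acids: A Fluorophenyl Replaces Hydroxy

The source may hold more compounds than are shown below. What is called first, only, known or untested is meant among the compounds shown, and "the series" means these compounds.

Measured compounds:
compound 1, `O=C(O)C1(Sc2ncnc3ccccc23)CCC1`, > 10000 nM
compound 2, `O=C1COc2cccc(SC3(C(=O)O)CCC3)c2N1`, > 10000 nM
compound 3, `O=C(O)C1(Sc2ccnc3ccc(O)cc23)CCC1`, > 10000 nM

In an assay on HEK293 cells for inhibition of solute carrier family 22 member 12 (Homo sapiens), read by scintillation counting, with a stated time of 12 min (a higher number here means a weaker inhibitor, a lower number a stronger inhibitor), compound 1 gives > 10000 nM, which is a limit of the assay and not a number. In this assay compound 2 likewise gives > 10000 nM, again a limit. Compound 3 also gives > 10000 nM in this assay, and this too is a limit. So compound 3 stands nowhere in particular among the three: every value shown is the same limit, and the limit of > 10000 nM in this assay, at which 3 of the 3 values shown sit, is all the evidence there is. For the measured compounds named here, no step between two measured compounds can be read from these data.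

Compound 4, `O=C(O)C1(Sc2ccnc3ccc(-c4ccc(F)cc4)cc23)CCC1`, differs from compound 3 in one place: 4-fluorophenyl in place of hydroxy on an aromatic carbon. The change swaps a small hydroxy for a 4-fluorophenyl on an aromatic carbon of the fused two-ring core. With only limits at hand, no pattern can be drawn; still, compound 4 is expected to move toward stronger inhibition in this assay, a step of an at least 3.3-fold lower number from compound 3 to compound 4 (0.52 log units; beyond the scatter) that would carry it past the limit into measurable territory. The estimate for compound 4 in this assay is therefore 3000 nM, within a range from 400 nM to 10000 nM.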

Compound 4, half-maximal inhibitory concentration: 159 nM
Estimate against measurement, compound 4: 19-fold (1.28 log units) above; the measured number lies below the stated range.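

On the six-membered aromatic ring of carbon only, part of the fused system of two rings, this position proves able to carry a large change in this assay: 4-fluorophenyl in place of hydroxy on this aromatic carbon gives an at least 62-fold lower number from compound 3 to compound 4 (1.79 log units; beyond the scatter). The value of compound 3, > 10000 nM, is a limit of the assay and not a number. Compound 4 is the only compound shown with a measured number in this assay, and no other step can be read: the limit of > 10000 nM in this assay, at which 3 of the 4 values shown sit.

The compounds shown do not separate the fluorine from the ring that carries it, and a plain phenyl or a 4-chlorophenyl on the same aromatic carbon would draw that line. They also leave open whether the carboxylic acid and the cyclobutane are still needed alongside the 4-fluorophenyl, a question that a primary amide in place of the acid or a cyclopropane in place of the cyclobutane would address.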